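A few compounds are considered here, and "the series" means these few. Any claim that something is new, unique, unknown or untested is made for them only; others in the source may bear on it.

Series notes, a functional assay on CCRF-CEM cells (Homo sapiens) for inhibition, read by MTT assay, with a stated time of 72 h; on this read-out higher numbers stand for weaker inhibition and lower numbers for stronger inhibition:
compound 1, `COc1cc(NC(C)CCCNC(=O)NNC(=O)Nc2cccc(F)c2)c2ncccc2c1`, 98000 nM
compound 2, `COc1cc(NC(C)CCCNC(=O)Nc2ccc(F)cc2)c2ncccc2c1`, 26000 nM
compound 3, `COc1cc(NC(C)CCCNC(=O)Nc2cccc(F)c2)c2ncccc2c1`, 21000 nM

Compound 2 holds the second highest of the three numbers in this assay; the step of a 1.2-fold lower number from compound 2 to compound 3 (0.09 log units; within the scatter) lies within the scatter, whereas a 3.8-fold lower number from compound 1 to compound 2 (0.58 log units; beyond the scatter) lies beyond it.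

Compound 4, `COc1cc(NC(C)CCCNC(=O)Nc2cccc(O)c2)c2ncccc2c1`, is not yet measured. The change is 3-hydroxyphenyl in place of 4-fluorophenyl on an amide-type nitrogen. Among the compounds with values here, the only step that bears on it is the exchange of 4-fluorophenyl for 3-fluorophenyl, a 1.2-fold lower number from compound 2 to compound 3 (0.09 log units; within the scatter), which changed little. Within the data shown here, no measured compound carries a hydroxyl on this ring, so nothing shows what that group adds. No step beyond the scatter is expected, a 1.2-fold higher number from compound 2 to compound 4 (0.06 log units; within the scatter). Compound 4 is estimated at 30000 nM, range 12000 nM to 75000 nM.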

Compound 4, half-maximal inhibitory concentration: 32000 nM
Estimate against measurement, compound 4: 1.1-fold (0.03 log units) below; the range from low to high includes it.
By their numbers in this assay, from the lowest: compounds 3, 2 and 4 (each within the scatter of the next); then compound 1.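

In this assay, the change to 3-hydroxyphenyl on this amide-type nitrogen gives no step beyond the scatter, either as a 1.2-fold higher number from compound 2 to compound 4 (0.09 log units; within the scatter) or, for hydroxy in place of fluoro on an aromatic carbon, as a 1.5-fold higher number from compound 3 to compound 4 (0.18 log units; within the scatter). The third comparison, a 3.1-fold lower number from compound 1 to compound 4 (0.49 log units; beyond the scatter), is modest and beyond the scatter, so compound 1 remains apart from the other three compounds. No available evidence bears on these results. As far as these compounds go, whether an amine or a carboxylic acid in place of the hydroxyl would give a step beyond the scatter remains open, as does the effect of a longer chain on this nitrogen.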